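Swapping a hydroxycyclohexyl for a thioether chain

The source may hold more compounds than are shown below. What is called first, only, known or untested is meant among the compounds shown, and "the series" means these compounds.

Measured compounds:
compound 1, `CC(C)c1n[nH]c2c(NCc3ccc(-c4ccccn4)cc3)nc(SCCC(N)=O)nc12`, 120 nM
compound 2, `CCC(O)CSc1nc(NCc2ccc(-c3ccccn3)cc2)c2[nH]nc(C(C)C)c2n1`, 273 nM
compound 3, `CC(C)c1n[nH]c2c(NCc3ccc(-c4ccccn4)cc3)nc(SC3CCCCC3O)nc12`, 636 nM

All three share one core and differ only in the group carried on the sulfur. In a functional assay on HT cells (Homo sapiens) for antiproliferative activity, read by fluorescence, with a stated time of 72 h (on this read-out higher numbers stand for weaker inhibition of growth and lower numbers for stronger inhibition of growth), compound 3 gives the highest number of the three, so it inhibits growth least: a 5.3-fold higher number from compound 1 to compound 3 (0.72 log units; beyond the scatter) and a 2.3-fold higher number from compound 2 to compound 3 (0.37 log units; beyond the scatter), both beyond the scatter. Between the two chain-bearing compounds the gap is smaller, a 2.3-fold higher number from compound 1 to compound 2 (0.36 log units; beyond the scatter).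

Compound 4, `CSCCSc1nc(NCc2ccc(-c3ccccn3)cc2)c2[nH]nc(C(C)C)c2n1`, is the next step from compound 3.
2-(methylsulfanyl)ethyl in place of 2-hydroxycyclohexyl on a sulfur

The two steps that reach compound 3 both traded an open chain for the ring and raised the number; compound 4 goes back to an open chain, so those steps, read in reverse, point to a lower number. The step from compound 1 to compound 2 shows that changing what the chain carries also moves the number, though modestly, and the new chain carries neither a hydroxyl nor an amide, unlike compound 1 and compound 2, so its size is uncertain. A modest fall is expected, a 2.1-fold lower number from compound 3 to compound 4 (0.33 log units; beyond the scatter). For compound 4 the estimate is 300 nM, with a range from 100 nM to 900 nM.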

Compound 4, concentration for 50% growth inhibition: 975 nM
Beside the measured number, compound 4's estimate is 3.3-fold (0.51 log units) below it; measured number above the stated range.
By their numbers in this assay, from the lowest: compound 1; then compound 2; then compounds 3 and 4 (each within the scatter of the next).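

In this assay, going back to an open chain does not by itself bring the number down: the step is a 1.5-fold higher number from compound 3 to compound 4 (0.19 log units; within the scatter), so 2-(methylsulfanyl)ethyl and 2-hydroxycyclohexyl on this sulfur cannot be told apart. Having a chain rather than a ring is therefore not enough to explain the lower numbers of compound 1 and compound 2, since what the chain carries also counts: the steps are a 3.6-fold higher number from compound 2 to compound 4 (0.55 log units; beyond the scatter) and an 8.1-fold higher number from compound 1 to compound 4 (0.91 log units; beyond the scatter), the second being the largest step in this set, with methylsulfanyl in place of carbamoyl, while compound 3, which keeps a hydroxyl on its ring, goes against any simple rule that a hydroxyl alone gives a low number. Nothing available here explains why these groups differ in this way.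

Still open, from the compounds shown here alone, is whether the low number of compound 1 belongs to the amide itself or would also come with another group at the end of the same chain, such as a carboxylic acid or an amine, or with a longer chain. A plain cyclohexyl on the sulfur would help separate the effect of the ring from that of its hydroxyl.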